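A phenyl swap on the tert-butyl compound

This account rests on a few compounds, and the source may have more. Where it says the series, first, only, none or still open, it means among the compounds named here.

Measured so far in a functional assay on MDA-MB-231 cells (Homo sapiens) for inhibition, read by MTT assay, with a stated time of 48 h (on this read-out higher numbers stand for weaker inhibition of growth and lower numbers for stronger inhibition of growth), are three compounds:
Compound 1 `Cc1cccc(Nc2ncnc3ccc(NC(=S)NCc4ccccc4)cc23)c1C` gives 28700 nM
Compound 2 `CC(C)c1ccc(Nc2ncnc3ccc(NC(=S)NCc4ccccc4)cc23)cc1` gives 12800 nM
Compound 3 `CC(C)(C)c1ccc(Nc2ncnc3ccc(NC(=S)NCc4ccccc4)cc23)cc1` gives 8700 nM

Compound 3 sits at the low end of these numbers. One step (a 1.5-fold lower number from compound 2 to compound 3 (0.17 log units; within the scatter)) lies within the scatter, while the other (a 3.3-fold lower number from compound 1 to compound 3 (0.52 log units; beyond the scatter)) lies beyond it. Compound 4 `S=C(NCc1ccccc1)Nc1ccc2ncnc(Nc3ccc(-c4ccccc4)cc3)c2c1` differs from compound 3 in one group, with phenyl in place of tert-butyl on an aromatic carbon. The nearest comparison is methyl in place of hydrogen (a 1.5-fold lower number from compound 2 to compound 3 (0.17 log units; within the scatter)), which stayed within the scatter. A wider change (a 2.2-fold lower number from compound 1 to compound 2 (0.35 log units; beyond the scatter)) was still modest. The expected step (a 1.1-fold lower number from compound 3 to compound 4 (0.04 log units; within the scatter)) is therefore none beyond the scatter, in either direction. Compound 4 is estimated at 8000 nM in this assay with 3500 nM to 18000 nM as the expected range.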

Compound 4, concentration for 50% growth inhibition: 8400 nM
For compound 4 the middle estimate is 1.1-fold (0.02 log units) below the measured one; the range from low to high includes it.
By their numbers in this assay, from the lowest: compounds 4, 3 and 2 (each within the scatter of the next); then compound 1.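

At this position, phenyl in place of tert-butyl gives a 1.0-fold lower number from compound 3 to compound 4 (0.02 log units; within the scatter) in this assay, and phenyl in place of isopropyl gives a 1.5-fold lower number from compound 2 to compound 4 (0.18 log units; within the scatter). The ringless groups on this carbon can thus give way to a six-membered aromatic ring, with more heavy atoms, without a change that can be told from the scatter. No evidence is available to explain this result. Still open, from the compounds shown here alone, is whether an amine or a carboxylic acid at this place would leave the number equally unchanged. Also open, going by these compounds, is how a pyridine ring would compare with phenyl here.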